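Methyl(neopentyl)carbamoyl for Isopropyl: Compound 4 Awaited

The compounds below may be only part of what the source reports. "The series", "measured", "known", "first", "only" and "open" are said of these compounds alone.

Three acids built on a shared core have been measured in a functional assay on cells for agonist activity at Free fatty acid receptor 1 (Homo sapiens), read by FLIPR and calcium flux, with a stated time of 60 min; on this read-out higher numbers stand for an effect only at larger amounts of compound and lower numbers for an effect already at smaller amounts. Compound 1 `COc1ccc(F)c(-c2ccc(COc3cccc([C@@H](CC(=O)O)C4CC4)c3)nc2CC(C)(C)C)c1` gives 150 nM in this assay. Compound 2 `COc1ccc(C(C)C)c(N2CCC(COc3cccc(C(CC(=O)O)C4CC4)c3)CC2)c1` gives 120 nM, and compound 3 `COc1ccc(CCCC(C)(C)C)c(N2CC(COc3cccc(C(CC(=O)O)C4CC4)c3)C2)c1` gives 250 nM. Compound 2 thus holds the lowest number of the three, but its separation from compound 1 lies within the scatter, while the gap to compound 3 lies beyond it, so compound 2 and compound 1 can only be called alike, with compound 3 behind both.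

Compound 4 `COc1ccc(C(=O)N(C)CC(C)(C)C)c(N2CCC(COc3cccc(C(CC(=O)O)C4CC4)c3)CC2)c1` is not yet measured. It differs from compound 2 in one place: methyl(neopentyl)carbamoyl in place of isopropyl on an aromatic carbon. Among the compounds with values here, no measured pair in the set shows this same change, so nothing here tells how large its effect will be or in which direction. The expectation for compound 4 therefore rests on compound 2 alone, because compound 2 gives 120 nM in this assay and compound 4 keeps everything else of that structure.

Compound 4 is expected to give about 200 nM in this assay, in a range from 60 nM to 700 nM. The step this estimate implies, a 1.7-fold higher number from compound 2 to compound 4 (0.22 log units; within the scatter), is expected to be small, not clearly beyond the scatter in either direction.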

Compound 4, half-maximal effective concentration: 100 nM
Estimate against measurement, compound 4: 2.0-fold (0.30 log units) above; the range from low to high includes it.
By their numbers in this assay, from the lowest: compounds 4, 2, 1 and 3 (each within the scatter of the next, the first and the last beyond it).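

In this assay the exchange of isopropyl for methyl(neopentyl)carbamoyl on this aromatic carbon, ortho to a large group and para to a methoxy group, gives a 1.2-fold lower number from compound 2 to compound 4 (0.08 log units; within the scatter) and so leaves compound 2 and compound 4 indistinguishable. The earlier compounds shown here offered no pair differing at this place; this pair shows that the read-out stays within the scatter even though the group grows from 3 heavy atoms to 9 and brings in a nitrogen and a carbonyl, with 1 hydrogen-bond acceptor, no ring and no net charge. No evidence at hand bears on why the two compounds match.

Open still is how far this place accepts other groups, such as an amine, a carboxylic acid or an amide that keeps the amide hydrogen in place of the methyl on nitrogen. Also open, as far as these compounds go, is whether methyl(neopentyl)carbamoyl would leave the number just as unmoved on the core of compound 1 or the core of compound 3.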